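Distal substituent changes in the shared core: working notes

A few compounds are considered here, and "the series" means these few. Any claim that something is new, unique, unknown or untested is made for them only; others in the source may bear on it.

Measured so far:
compound 1 `Oc1ccccc1CNc1ccc(-c2ccccc2)cc1` — 1820 nM
compound 2 `CC(C)(C)c1ccc(-c2ccc(NCc3ccccc3O)cc2)cc1` — "not active" (no number reported)

In a functional assay on Jurkat cells (Homo sapiens) for activation, with a stated time of 24 h (a higher number here means that more compound is needed for the effect, a lower number that less compound is needed), compound 1 gives 1820 nM. Compound 2 is reported in this assay as "not active" (no number reported), so no number stands for it and it offers no footing for a counted step. Compound 3 `Oc1ccccc1CNc1ccc(-c2ccc(-c3ccccc3)cc2)cc1` differs from compound 2 by phenyl in place of tert-butyl on an aromatic carbon, para to a large group. Within the data shown here, no step between measured compounds exists, so the expected size of the change in this assay cannot be anchored on the series itself; the only guides are that compound 1 shows a number and compound 2 does not. The expectation for compound 3 is weak activity, with a real chance that only a limit is reported. Compound 3 is estimated at 6000 nM in this assay, expected within 1500 nM to 30000 nM.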

Compound 3, half-maximal effective concentration: "not active" (no number reported)
For compound 3 the study gives words and no number, so the estimate cannot be set against anything.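

No new step can be read: in this assay compound 2 and compound 3 both carry only the words "not active", without a number. No evidence on hand bears on this result. Among these compounds, compound 1 at 1820 nM remains the only number, leaving open how distal substituents on the shared core shift activity.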